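This account rests on a few compounds, and the source may have more. Where it says the series, first, only, none or still open, it means among the compounds named here.

Working notes on the series.

Of the compounds shown here, two have numbers so far. Compound 1, `O=C(O)CCc1ccc(NCc2ccc(Cl)cc2)cc1`, gives in a functional assay on CHO cells for agonist activity at Free fatty acid receptor 1 (Homo sapiens), read by reporter gene assay (a higher number here means a larger maximal response, a lower number a smaller maximal response), a value of 111%. Compound 2, `O=C(O)C1CC1c1ccc(NCc2cccc(Oc3ccccc3)c2)cc1`, gives in this assay a value of 74%. On the two numbers shown compound 2 stands lowest; its nearest neighbour is compound 1, whose value lies higher by a gap that is beyond the usual scatter of repeated measurements. Within the data shown here, no pair of measured compounds differs in only one place, so no single-point step can be read off the measured set.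

Compound 3, `CC(C(=O)O)c1ccc(NCc2cccc(Oc3ccccc3)c2)cc1`, is the next to be measured in this assay. It differs from compound 2 in one place: 1-carboxyethyl in place of 2-carboxycyclopropyl on an aromatic carbon. The acid-bearing part of compound 3 carries no ring, which on the counted difference is the only thing that sets it apart from compound 2. With only the two values of compound 1 and compound 2 to go on, the step from compound 2 to compound 3 in this assay is expected to be small, upward, and likely within the scatter, as a number 11 percentage points higher from compound 2 to compound 3 (beyond the scatter). Compound 3 is therefore estimated at 85% in this assay, with a range from 65% to 108%.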

Compound 3, largest response reached (reported as percent of maximum), in percent of the reference or control that the assay uses: 34%
For compound 3 the middle estimate is 51 percentage points above the measured one; measured number below the stated range.
By their numbers in this assay, from the lowest: compound 3; then compound 2; then compound 1.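

The acid-bearing group on the aromatic carbon para to a large group is now shown to matter in this assay: 1-carboxyethyl in place of 2-carboxycyclopropyl gives a number 40 percentage points lower from compound 2 to compound 3 (beyond the scatter), the first single-place step in the series. On the counts, the two groups have the same hydrogen-bond donors, hydrogen-bond acceptors, net charge and double bonds outside aromatic rings, while the three-membered ring is present only in 2-carboxycyclopropyl, so the maximal response at this position is not set by those shared counts alone. No measurement available here explains the drop.

A single step cannot separate the loss of the ring from the change in how the carboxylic acid is attached, and compound 1 differs from compound 3 in more than one place, so it cannot settle this. As far as these compounds go, it remains open where a carboxymethyl or 3-carboxypropyl group on the same aromatic carbon, with the rest of compound 3 unchanged, would fall relative to compound 2 and compound 3.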